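The compounds below may be only part of what the source reports. "The series", "measured", "known", "first", "only" and "open" are said of these compounds alone.

Working notes on the series.

Compound 1 `CN1C[C@H](C(=O)Nc2ccccc2)[C@@H](c2ccc(/C=C/C(=O)Nc3ccccc3N)cc2)C1` carries an unsubstituted phenyl on the amide-type nitrogen. In an in vitro ADME assay on microsomes from liver (Homo sapiens) for pharmacokinetics, read by LC-MS, with a stated time of 10 min, tested at 1 uM (a higher number here means faster removal of the compound, a lower number slower removal), compound 1 gives 7 mL/min/kg. Compound 2 `COc1ccc(NC(=O)[C@H]2CN(C)C[C@@H]2c2ccc(/C=C/C(=O)Nc3ccccc3N)cc2)cc1` gives 14 mL/min/kg in this assay, and compound 3 `COc1cccc(NC(=O)[C@H]2CN(C)C[C@@H]2c2ccc(/C=C/C(=O)Nc3ccccc3N)cc2)c1` gives 14 mL/min/kg. Compound 1 sits at the low end of these three numbers, yet neither gap reaches beyond the scatter: a 2.0-fold higher number from compound 1 to compound 2 (0.30 log units; within the scatter) and a 2.0-fold higher number from compound 1 to compound 3 (0.30 log units; within the scatter), and no change at the digits printed from compound 2 to compound 3 (within the scatter).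

Compound 4 `CN1C[C@H](C(=O)Nc2ccc(F)c(Br)c2)[C@@H](c2ccc(/C=C/C(=O)Nc3ccccc3N)cc2)C1` has not been measured in this assay. It differs from compound 1 in one place: 3-bromo-4-fluorophenyl in place of phenyl on an amide-type nitrogen. The measured steps that bear on this are the two methoxy substitutions on the same ring, both of which stayed within the scatter; no halogen substitution on that ring has been measured in this set. Given that the only recorded changes on this ring, a 2.0-fold higher number from compound 1 to compound 2 (0.30 log units; within the scatter) and a 2.0-fold higher number from compound 1 to compound 3 (0.30 log units; within the scatter), moved the number by so little, compound 4 is expected to show a 1.4-fold higher number from compound 1 to compound 4 (0.15 log units; within the scatter), a step no larger than the scatter. The estimate for compound 4 is 10 mL/min/kg, with a range from 5 mL/min/kg to 22 mL/min/kg.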

Compound 4, clearance: 15 mL/min/kg
For compound 4 the middle estimate is 1.5-fold (0.18 log units) below the measured one; measured number inside the range.
By their numbers in this assay, from the lowest: compounds 1, 2, 3 and 4 (each within the scatter of the next, the first and the last beyond it).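

In this assay, going by these compounds alone, the 3-bromo-4-fluorophenyl on the amide-type nitrogen gives the first step at this position that passes the scatter (a 2.1-fold higher number from compound 1 to compound 4 (0.33 log units; beyond the scatter)), though it remains modest. The same group cannot be told apart from either methoxy-substituted ring (a 1.1-fold higher number from compound 3 to compound 4 (0.03 log units; within the scatter); a 1.1-fold higher number from compound 2 to compound 4 (0.03 log units; within the scatter)), so compounds 2, 3 and 4 show no separation despite carrying different substituents on this ring. Nothing measured here accounts for the step from the unsubstituted phenyl.

Whether the step belongs to the bromine, the fluorine or the two together stays open, as 3-bromophenyl and 4-fluorophenyl do not appear among these compounds. Also open, as far as these compounds go, is how this assay would read for a ring carrying an amine or a carboxylic acid.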